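Sulfonyl sulfur group change from compound 2 to compound 3

The source may hold more compounds than are shown below. What is called first, only, known or untested is meant among the compounds shown, and "the series" means these compounds.

In an ADME assay on microsomes from liver (Homo sapiens) for pharmacokinetics, read by LC-MS, with a stated time of 60 min, tested at 1 uM (a higher number here means faster removal of the compound, a lower number slower removal), compound 1 (`O=C(NCc1ccc(S(=O)(=O)N2CCC(O)CC2)cc1)N1Cc2ccncc2C1`) gives 6 mL/min/kg and compound 2 (`CN1CCN(S(=O)(=O)c2ccc(CNC(=O)N3Cc4ccncc4C3)cc2)CC1`) gives 9 mL/min/kg as its value, so compound 2 stands within the scatter of compound 1. Compound 3 (`O=C(NCc1ccc(S(=O)(=O)N2CC3(CCOCC3)C2)cc1)N1Cc2ccncc2C1`) differs from compound 2 by a group of 9 heavy atoms (7 carbon, 1 nitrogen, 1 oxygen; one four-membered non-aromatic ring with 1 hetero atom, one six-membered non-aromatic ring with 1 hetero atom) in place of a group of 7 heavy atoms (5 carbon, 2 nitrogen; one six-membered non-aromatic ring with 2 hetero atoms), on a sulfonyl sulfur at the same sulfonyl sulfur. Among the compounds with values here, the only measured step at that sulfur is a 1.5-fold higher number from compound 1 to compound 2 (0.18 log units; within the scatter) and it bears directly on this change. No step beyond the scatter is therefore expected in this assay and the estimated step is a 1.1-fold lower number from compound 2 to compound 3 (0.05 log units; within the scatter) on this evidence. Compound 3 is estimated at 8 mL/min/kg with an expected range of 4 mL/min/kg to 16 mL/min/kg as a working figure.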

Compound 3, clearance in the Homo sapiens assay: 13 mL/min/kg
Beside the measured number, compound 3's estimate is 1.6-fold (0.21 log units) below it, and the stated range covers the measured number.
By their numbers in the Homo sapiens assay, from the lowest: compounds 1, 2 and 3 (each within the scatter of the next, the first and the last beyond it).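

Within the data shown here, in the Homo sapiens assay, at the sulfonyl sulfur, the group with a four-membered and a six-membered ring gives a 1.4-fold higher number from compound 2 to compound 3 (0.16 log units; within the scatter) against 4-methylpiperazin-1-yl, while against the hydroxypiperidine of compound 1 it gives a 2.2-fold higher number from compound 1 to compound 3 (0.34 log units; beyond the scatter) as the first step at this position beyond the scatter. In a physicochemical assay for solubility, in phosphate buffer, with a stated time of 24 h, at pH 7.4, tested at 100 uM (on this read-out lower numbers stand for lower solubility and higher numbers for higher solubility), compound 2 gives 160000 nM and compound 3 gives 272000 nM. In the physicochemical assay the change gives a 1.7-fold higher number from compound 2 to compound 3 (0.23 log units; within the scatter) and so shows no step beyond the scatter. No measurement at hand offers an explanation for these steps. Open, on these data alone, is how an open-chain group such as dimethylamino or a carboxylic acid on the sulfonyl sulfur would read in the Homo sapiens assay and the physicochemical assay. Also open, as far as these compounds go, is whether these steps would hold on another core.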